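From Octyl to Cyclopentyl on a Sulfur

The source may hold more compounds than are shown below. What is called first, only, known or untested is meant among the compounds shown, and "the series" means these compounds.

In an ADME assay on HFF cells (Homo sapiens) for cytotoxicity, with a stated time of 8 days (on this read-out lower numbers stand for higher toxicity in this test and higher numbers for lower toxicity in this test), compound 1 `CN(C)c1nc(N)nc2c1ncn2/C=C1/CC1(CO)CO` gives > 300000 nM as a limit of the assay, not a number. Compound 2 `Nc1nc(OCc2ccccc2)c2ncn(/C=C3/CC3(CO)CO)c2n1` gives > 300000 nM as a limit too. Compound 3 `CCCCCCCCSc1nc(N)nc2c1ncn2/C=C1/CC1(CO)CO` gives > 300000 nM as a limit as well. The whole record so far is the limit of > 300000 nM in this assay, at which 3 of the 3 values shown sit, and nothing finer. Compound 4 `Nc1nc(SC2CCCC2)c2ncn(/C=C3/CC3(CO)CO)c2n1` differs cyclopentyl in place of octyl on a sulfur by carrying cyclopentyl in place of octyl on a sulfur. The measured changes are a step that the two limits leave unreadable from compound 1 to compound 2 and a step that the two limits leave unreadable from compound 1 to compound 3 and a step that the two limits leave unreadable from compound 2 to compound 3 with no size to carry over. The expected a number no higher from compound 3 to compound 4 (the limit leaves the size open) is therefore no move beyond the scatter in this assay in either direction. Compound 4 is estimated at 300000 nM with an expected range from 150000 nM to 600000 nM and will probably be reported as a limit again.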

Compound 4, half-maximal cytotoxic concentration: > 300000 nM
Compound 4 gave a limit, no number; the forecaster's own chance of this, stated with the estimate: 85%; the middle value lies on the limit itself.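

In this assay compound 4 gives only a limit, so no step linking it to compound 1, compound 2 or compound 3 can be read: the limit of > 300000 nM in this assay, at which 4 of the 4 values shown sit.

The compounds shown leave open at what concentration, if any, each one harms these cells.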